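This account rests on a few compounds, and the source may have more. Where it says the series, first, only, none or still open, it means among the compounds named here.

Three compounds have been measured in a functional assay on MGC-803 cells (Homo sapiens) for inhibition, read by MTT assay, with a stated time of 72 h; a lower number here means a stronger inhibitor, a higher number a weaker inhibitor:

compound 1, `Cc1cc(Nc2cc(-c3ccccc3)[nH]n2)n2nc(SCc3csc4ccccc34)nc2n1`, gives 2280 nM
compound 2, `Cc1cc(Nc2cc(-c3ccc(Cl)cc3)[nH]n2)n2nc(SCc3ccc(Br)cc3)nc2n1`, gives 2780 nM
compound 3, `Cc1cc(Nc2ccn(Cc3ccccc3)n2)n2nc(SCc3ccc(Br)cc3)nc2n1`, gives 4720 nM

Compound 1 has the lowest number of the three. The value of compound 2 lies within the usual scatter of that of compound 1, so the two cannot be told apart. Compound 3 lies beyond the scatter, so compound 3 is a weaker inhibitor than compound 1.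

Compound 4, `Cc1cc(Nc2cc(-c3ccccc3)[nH]n2)n2nc(SCC(=O)c3ccccc3)nc2n1`, has not yet been measured. It differs from compound 1 in one place: benzoyl in place of 1-benzothiophen-3-yl on a saturated chain carbon bound to a sulfur. No measured pair shows a change of this kind, so there is no shown step to lean on; the three measured values sit close together, and the change keeps one six-membered aromatic ring of carbon only. The expected step is a 1.3-fold higher number from compound 1 to compound 4 (0.12 log units; within the scatter), small and, if anything, toward a weaker inhibitor, likely not beyond the scatter. Compound 4 is therefore estimated at 3000 nM, with a range from 1200 nM to 7500 nM.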

Compound 4, half-maximal inhibitory concentration: 2580 nM
For compound 4 the middle estimate is 1.2-fold (0.07 log units) above the measured one, and the stated range covers the measured number.
By their numbers in this assay, from the lowest: compounds 1, 4, 2 and 3 (each within the scatter of the next, the first and the last beyond it).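

In this assay the change on a saturated chain carbon bound to a sulfur, benzoyl in place of 1-benzothiophen-3-yl, gives a 1.1-fold higher number from compound 1 to compound 4 (0.05 log units; within the scatter) and the two compounds cannot be told apart. This is the first step shown that changes one place only, and it shows that a single carbon-only aromatic ring with a carbonyl reads the same here as the larger group with its two aromatic rings and its sulfur. The data shown offer no measured explanation for this match.

The compounds shown leave open whether this position would read the same with a group that has no aromatic ring at all, such as an amine or a carboxylic acid. As far as these compounds go, it also remains open what a longer chain carrying the benzoyl, or a chlorine on its ring, would do to the number.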